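The source may report more compounds than this note shows. Statements on the series, on what has been measured and on what is new or still open speak of the compounds shown alone.

Measured compounds:
Compound 1 `O=C(NO)c1cc2ccc(OCc3ccccc3)cc2oc1=O` gives 39500 nM in a functional assay on HCT-116 cells (Homo sapiens) for cytotoxicity, read by MTT assay, with a stated time of 72 h; on this read-out lower numbers stand for stronger inhibition and higher numbers for weaker inhibition.
Compound 2 `CCOc1ccc2cc(C(=O)NN)c(=O)oc2c1` gives only a limit, > 100000 nM, in this assay.

Compound 2 therefore stands at the limit of this assay, and one of the two values shown sits there (the limit of > 100000 nM in this assay, at which 1 of the 2 values shown sits). For the measured compounds named here, the other value, that of compound 1, is a real number, but compound 1 and compound 2 differ in more than one place, so no single step between them can be read from these two results; all that can be said is that compound 1 has a measured number and compound 2 does not.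

Compound 3 `NNC(=O)c1cc2ccc(OCc3ccccc3)cc2oc1=O` has not yet been measured. It differs from compound 2 in one place: phenyl in place of methyl on a saturated chain carbon bound to an oxygen on an aromatic ring. No measured step of this kind exists among the shown compounds, so the expectation rests on the structural change alone. The expected step from compound 2 to compound 3 in this assay is an at least 1.4-fold lower number from compound 2 to compound 3 (0.15 log units; that floor lies within the scatter), a move toward stronger inhibition that may or may not clear the usual scatter. Compound 3 is accordingly estimated at 70000 nM, within a range of 25000 nM to 200000 nM, and there is a fair chance that this assay again reports only a limit for it.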

Compound 3, half-maximal inhibitory concentration: > 100000 nM
Compound 3: a limit, no number; the forecaster's own chance of this, stated with the estimate: 45%; middle value at least 1.4-fold (0.15 log units) from the limit.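

In this assay compound 3 gives > 100000 nM, which is a limit and not a number. Amino in place of hydroxy on an amide-type nitrogen gives an at least 2.5-fold higher number from compound 1 to compound 3 (0.40 log units; beyond the scatter), the first single change in this set whose size can be read, and it points toward weaker inhibition, with the true size of the step possibly larger than this floor. The step for phenyl in place of methyl cannot be read, so no effect of that change can be stated, since compound 2 and compound 3 both end at the same limit: the limit of > 100000 nM in this assay, at which 2 of the 3 values shown sit.

The compounds shown leave open how far beyond the limit compound 2 and compound 3 really lie, and whether swapping ethyl for benzyl would matter at all in a compound that keeps the hydroxy group on the amide-type nitrogen. They also leave open what other groups on that nitrogen would do, such as methoxy in place of hydroxy or a methyl in place of the amino group, and whether any of these would give a measurable number in this assay.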